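Extending Ethyl to Butyl on the Shared Core

The source may hold more compounds than are shown below. What is called first, only, known or untested is meant among the compounds shown, and "the series" means these compounds.

Compound 1 `C=C1C(=O)[C@@]23C(=O)OC[C@]4([C@@H](OC(C)=O)CCC(C)(C)[C@H]4C=O)[C@@H]2CC[C@H]1[C@H]3OC(=O)CC`: 2770 nM
Compound 2 `C=C1C(=O)[C@@]23C(=O)OC[C@]4([C@@H](OC(C)=O)CCC(C)(C)[C@H]4C=O)[C@@H]2CC[C@H]1[C@H]3OC(=O)c1ccc([N+](=O)[O-])cc1`: 1600 nM

In a functional assay on CaEs17 cells (Homo sapiens) for inhibition, read by MTT assay (a lower number here means a stronger inhibitor, a higher number a weaker inhibitor), compound 1 gives 2770 nM and compound 2 gives 1600 nM. Among the measured compounds shown here, these two values lie within the scatter of each other, so compound 1 cannot be ranked against its only neighbour. Compound 3 `C=C1C(=O)[C@@]23C(=O)OC[C@]4([C@@H](OC(C)=O)CCC(C)(C)[C@H]4C=O)[C@@H]2CC[C@H]1[C@H]3OC(=O)CCCC` keeps the core of compound 1 and carries one change: ethyl in place of hydrogen on a saturated chain carbon, two bonds along the chain from a carbonyl carbon. Cut one bond further out, this reads ethyl to butyl. For the measured compounds named here, the one measured step that bears on it is a 1.7-fold lower number from compound 1 to compound 2 (0.24 log units; within the scatter), where 4-nitrophenyl replaces that same ethyl on a carbonyl carbon. A larger replacement at this group thus produced no step beyond the scatter, although a single step is thin evidence. The expected step is a 1.1-fold lower number from compound 1 to compound 3 (0.04 log units; within the scatter), which is none beyond the scatter. For compound 3 the estimated value is 2500 nM, with an expected range of 1200 nM to 5000 nM.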

Compound 3, half-maximal inhibitory concentration: 2850 nM
For compound 3 the middle estimate is 1.1-fold (0.06 log units) below the measured one; the measured number falls inside the stated range.
By their numbers in this assay, from the lowest: compounds 2, 1 and 3 (each within the scatter of the next).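

In this assay, the ethyl added two bonds along the chain from a carbonyl carbon gives a 1.0-fold higher number from compound 1 to compound 3 (0.01 log units; within the scatter), so a straight chain, like the 4-nitrophenyl before it, produces no step beyond the scatter at this place. Butyl in place of 4-nitrophenyl on a carbonyl carbon gives a 1.8-fold higher number from compound 2 to compound 3 (0.25 log units; within the scatter), so these two groups cannot be ranked against each other either, and ethyl, butyl and 4-nitrophenyl now all sit within the scatter at this one position. No evidence at hand bears on why the three groups read alike.

The compounds shown leave open whether a chain longer than butyl, or a different kind of group on this carbonyl carbon, such as an amine or a carboxylic acid, would give a step beyond the scatter.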